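Replacing 4-hydroxyphenyl with 3,4-dimethoxyphenyl on the shared core

The compounds below may be only part of what the source reports. "The series", "measured", "known", "first", "only" and "open" are said of these compounds alone.

Of the compounds shown here, three with the same core have been measured in a physicochemical assay for lipophilicity; a lower number here means a more polar compound, a higher number a more lipophilic compound. Compound 1 `C[C@H]1CC[C@@H]2[C@@H](OC(=O)[C@]23CC(c2ccc(Cl)cc2)=NO3)[C@]2(C)C(=O)C=C[C@@]12O`, with chloro on an aromatic carbon, gives 2.09. Compound 2 `C[C@H]1CC[C@@H]2[C@@H](OC(=O)[C@]23CC(c2ccc(N(C)C)cc2)=NO3)[C@]2(C)C(=O)C=C[C@@]12O`, with dimethylamino on that carbon, gives 1.51. Compound 3 `C[C@H]1CC[C@@H]2[C@@H](OC(=O)[C@]23CC(c2ccc(O)cc2)=NO3)[C@]2(C)C(=O)C=C[C@@]12O`, with hydroxy there, gives 0.932, the lowest of the three numbers.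

The next compound to be measured is compound 4 `COc1ccc(C2=NO[C@]3(C2)C(=O)O[C@@H]2[C@H]3CC[C@H](C)[C@]3(O)C=CC(=O)[C@@]23C)cc1OC`. It has 3,4-dimethoxyphenyl in place of 4-hydroxyphenyl on a carbon with a double bond to nitrogen.

Among the compounds with values here, two measured steps bear on this change, since both bring hydroxy in: a number 1.16 log units lower from compound 1 to compound 3 (beyond the scatter) and a number 0.58 log units lower from compound 2 to compound 3 (beyond the scatter). Compound 4 has no hydroxy, so its step should run the opposite way. Within the data shown here, no measured compound carries methoxy groups, however, so the data cannot show how far the number will move. Taking the smaller step, a number 0.58 log units lower from compound 2 to compound 3 (beyond the scatter), as the guide, a modest rise is expected in this assay. The estimated change is a number 0.62 log units higher from compound 3 to compound 4 (beyond the scatter). The number expected for compound 4 is 1.55, with an estimated range from 1.15 to 1.95.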

Compound 4, partition coefficient: 1.06
Beside the measured number, compound 4's estimate is 0.49 log units above it; the whole stated range lies above it.
By their numbers in this assay, from the lowest: compounds 3 and 4 (each within the scatter of the next); then compound 2; then compound 1.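

Going from 4-hydroxyphenyl to 3,4-dimethoxyphenyl at this position gives a number 0.13 log units higher from compound 3 to compound 4 (within the scatter) in this assay, although the group goes from 1 hydrogen-bond donor to 0 and gains heavy atoms. Among the earlier compounds, the only one with hydroxy had the lowest number, but these results show that a group without hydroxy can sit level with it on this scale, so hydroxy is not needed for a number this low. The other two comparisons point the same way, with a number 0.45 log units lower from compound 2 to compound 4 (beyond the scatter) and a number 1.03 log units lower from compound 1 to compound 4 (beyond the scatter), placing the 3,4-dimethoxyphenyl compound clearly under both the 4-(dimethylamino)phenyl and 4-chlorophenyl compounds. Nothing available here gives a measured explanation for this order of the groups.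

The compounds shown leave open how much each methoxy group contributes, a question that a 4-methoxyphenyl group, carrying a single methoxy, would help to separate. On these data alone, it also remains open where this assay would place a phenyl ring bearing a carboxylic acid or a primary amine on the same shared core.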